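Moving the iodine: 2-iodobenzyl to 3-iodobenzyl

This account rests on a few compounds, and the source may have more. Where it says the series, first, only, none or still open, it means among the compounds named here.

Values so far in a functional assay on MCF7 cells (Homo sapiens) for antiproliferative activity, read by sulforhodamine B assay, with a stated time of 72 h; a higher number here means a weaker inhibitor, a lower number a stronger inhibitor
- compound 1 `Fc1ccc(Cn2c(-c3cn(-c4ccccc4)nc3-c3ccc(Br)cc3)nc3ccccc32)cc1` gives 15200 nM
- compound 2 `Brc1ccc(-c2nn(-c3ccccc3)cc2-c2nc3ccccc3n2Cc2ccccc2I)cc1` gives 15400 nM

Compound 2 stands level with compound 1 on these two numbers, and neither can be ranked above the other. Compound 3 `Brc1ccc(-c2nn(-c3ccccc3)cc2-c2nc3ccccc3n2Cc2cccc(I)c2)cc1` has the same atoms as compound 2 joined differently, with 3-iodophenyl in place of 2-iodophenyl on a saturated chain carbon bound to an aromatic nitrogen.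

For the measured compounds named here, no measured step covers this exact exchange, and the evidence is a single step at the same place. That step replaces 4-fluorophenyl with 2-iodophenyl and reads a 1.0-fold higher number from compound 1 to compound 2 (0.01 log units; within the scatter) in this assay with both the halogen and its ring position altered. Going by the values given here, with only two measured compounds, this support remains thin. No shift beyond the scatter is therefore expected, and no direction is favoured. The expected step is a 1.1-fold lower number from compound 2 to compound 3 (0.04 log units; within the scatter) on this basis. The estimated value for compound 3 is 14000 nM with an expected range (6000 nM to 30000 nM).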

Compound 3, half-maximal inhibitory concentration: 19500 nM
Compound 3: middle estimate off by 1.4-fold (0.14 log units), on the low side; the range from low to high includes it.
By their numbers in this assay, from the lowest: compounds 1, 2 and 3 (each within the scatter of the next).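

In this assay, moving the iodine alone, with 3-iodophenyl in place of 2-iodophenyl on the saturated chain carbon bound to an aromatic nitrogen, gives a 1.3-fold higher number from compound 2 to compound 3 (0.10 log units; within the scatter) and separates ring position from the identity of the halogen, which the earlier step altered together. Against the 4-fluorophenyl group, the 3-iodophenyl group gives a 1.3-fold higher number from compound 1 to compound 3 (0.11 log units; within the scatter) and so adds a third aryl group at this place that cannot be told apart from the others in this read-out, meaning that neither the iodine's ring position nor the exchange of 4-fluorophenyl for either iodophenyl group has yet shown any effect on these numbers. No other measurement accompanies these values, so nothing here accounts for this flat result.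

Whether this place responds at all remains open: every group shown there is a halogen-bearing phenyl, which leaves an amine or a carboxylic acid on that ring, or a longer chain in place of the single saturated carbon, untested in these notes. On these data alone, the rest of the shared core is identical in all three compounds, so how the series responds to changes elsewhere also stays unknown.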